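Ring amide nitrogen: butyl to cyclohexyl in the series

The compounds below may be only part of what the source reports. "The series", "measured", "known", "first", "only" and "open" are said of these compounds alone.

Compound 3 `CCCCN1Cc2ccc(C(=O)N(C)CCC3CCNCC3)cc2CC(CC(=O)O)C1=O` gives 31 nM in a functional assay (plasma) for inhibition, with Homo sapiens as the target; a higher number here means a weaker inhibitor, a lower number a stronger inhibitor. Among the three measured compounds this is the lowest number, but the margin is uneven: compound 1 `CN(CCC1CCNCC1)C(=O)c1ccc2c(c1)CC(CC(=O)O)C(=O)N(Cc1ccccc1)C2` gives 36 nM, and the step of a 1.2-fold lower number from compound 1 to compound 3 (0.06 log units; within the scatter) is within the scatter, so compound 3 and compound 1 cannot be put in order. Compound 2 `CN(CCC1CCNCC1)C(=O)c1ccc2c(c1)CC(CC(=O)O)C(=O)NC2` gives 71 nM, and the step of a 2.3-fold lower number from compound 2 to compound 3 (0.36 log units; beyond the scatter) is the only one in this set that goes beyond the scatter.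

Compound 4 `CN(CCC1CCNCC1)C(=O)c1ccc2c(c1)CC(CC(=O)O)C(=O)N(C1CCCCC1)C2` differs from compound 3 in one place: cyclohexyl in place of butyl on an amide-type nitrogen in a ring

For the measured compounds named here, three measured steps touch the same position. The step of a 2.0-fold higher number from compound 1 to compound 2 (0.29 log units; within the scatter) is within the scatter, as is the step of a 1.2-fold lower number from compound 1 to compound 3 (0.06 log units; within the scatter). Going by the values given here, the one modest step, a 2.3-fold lower number from compound 2 to compound 3 (0.36 log units; beyond the scatter), concerns whether a carbon group is present on that nitrogen at all, not which carbon group it is. Benzyl, butyl and, by way of compound 1 and compound 3, the phenyl-to-propyl exchange on the attached chain carbon all give numbers within the scatter of one another. Compound 4 keeps a carbon group at this nitrogen, so the estimated step is a 1.1-fold higher number from compound 3 to compound 4 (0.05 log units; within the scatter), expected to stay within the scatter. Compound 4 is therefore estimated at 35 nM, with a range from 15 nM to 80 nM.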

Compound 4, half-maximal inhibitory concentration: 49 nM
Estimate against measurement, compound 4: 1.4-fold (0.15 log units) below; low and high end bracket the measured number.
By their numbers in this assay, from the lowest: compounds 3, 1, 4 and 2 (each within the scatter of the next, the first and the last beyond it).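

Cyclohexyl on the amide-type nitrogen brings a ring of carbon only to this position, and in this assay it cannot be told apart from the open-chain butyl, with a 1.6-fold higher number from compound 3 to compound 4 (0.20 log units; within the scatter), or from benzyl, with a 1.4-fold higher number from compound 1 to compound 4 (0.13 log units; within the scatter). The step from hydrogen does not repeat what butyl showed: a 1.4-fold lower number from compound 2 to compound 4 (0.16 log units; within the scatter) stays within the scatter, so cyclohexyl joins benzyl in this respect. Any pattern of a carbon group on this nitrogen outperforming hydrogen therefore rests on compound 3 alone, and compound 1 and compound 4 go against it, which leaves the single step beyond the scatter looking more like an edge case than a rule for the position.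

Going by these compounds, whether a group carrying a hydroxyl or an amine on this nitrogen, or a longer chain such as octyl, would move the number beyond the scatter from butyl remains open. No independent data bear on why these carbon groups give such close numbers, so the closeness stands as an observation only.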